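The source may report more compounds than this note shows. Statements on the series, on what has been measured and on what is new or still open speak of the compounds shown alone.

Values in an ADME assay on MRC5 cells (Homo sapiens) for cytotoxicity, read by fluorescence, with a stated time of 24 h; a higher number here means a weaker inhibitor, a lower number a stronger inhibitor:
- compound 1 `O=C(CC1S/C(=N\N=C\c2c(-c3ccccc3)[nH]c3ccccc23)NC1=O)c1ccccc1`: > 50000 nM, a limit of the assay
- compound 2 `CC(=O)OCCC1S/C(=N\N=C\c2c(-c3ccccc3)[nH]c3ccccc23)NC1=O`: 42800 nM
- compound 3 `O=C1N/C(=N/N=C/c2c(-c3ccc(Br)cc3)[nH]c3ccccc23)SC1CCO`: 15900 nM

Among the actual numbers in this assay, compound 2 at 42800 nM is the higher of the two, and compound 3 at 15900 nM is the nearest, with the gap beyond the scatter. The remaining result is a limit and not a number.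

The next compound is compound 4 `O=C(CC1S/C(=N\N=C\c2c(-c3ccccc3)[nH]c3ccccc23)NC1=O)c1ccc(F)cc1`. The change from compound 2 is (4-fluorophenyl)carbonyl in place of acetoxymethyl on a saturated chain carbon bound to a saturated ring carbon.

For the measured compounds named here, one measured step bears on this place: an at least 1.1-fold lower number from compound 1 to compound 2 (0.06 log units; that floor lies within the scatter), with benzoyl leaving and acetoxymethyl entering. The change to compound 4 runs the other way, with an aryl carbonyl group entering and acetoxymethyl leaving. That step is small, so no step beyond the scatter is expected in this assay, though any shift is expected to be towards a higher number. A report as a limit is also expected to be a real possibility for compound 4, because the limit of > 50000 nM in this assay, at which 1 of the 3 values shown sits, belongs to compound 1, the benzoyl member.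

The estimate amounts to an expected 1.1-fold higher number from compound 2 to compound 4 (0.05 log units; within the scatter). For compound 4 the estimated value is 48000 nM, with an expected range of 22000 nM to 90000 nM.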

Compound 4, half-maximal inhibitory concentration: 49800 nM
Beside the measured number, compound 4's estimate is 1.0-fold (0.02 log units) below it, within the range that was stated.
By their numbers in this assay, from the lowest: compound 3; then compounds 2 and 4 (each within the scatter of the next). At a limit, above all of these: compound 1.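

In this assay, (4-fluorophenyl)carbonyl in place of acetoxymethyl on a saturated chain carbon bound to a saturated ring carbon gives a 1.2-fold higher number from compound 2 to compound 4 (0.07 log units; within the scatter). In this one pair, an exchange that brings in a six-membered aromatic ring and changes the heavy-atom count from 5 to 9 leaves the two values within the scatter of each other, so this place tolerates the difference between these two groups in this assay without a readable change. Fluoro in place of hydrogen on an aromatic carbon gives a number no higher from compound 1 to compound 4 (the limit leaves the size open) and this step cannot be read. Compound 1 stands as a limit and not a number: the limit of > 50000 nM in this assay, at which 1 of the 4 values shown sits.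

Going by these compounds, it remains open whether a different group at this place, such as an amine, a carboxylic acid or a longer chain, would give a step beyond the scatter. On these data alone, compound 3 differs from the other compounds in more than one place, so the separate contributions of its bromo group and its chain also remain open.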